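The source may hold more compounds than are shown below. What is called first, only, known or untested is meant among the compounds shown, and "the series" means these compounds.

Measured compounds:
compound 1, `COc1ccc(F)cc1N1C(=O)CSC1c1cccc(C(=O)NCCCCc2ccccc2)c1`: 32%
compound 2, `O=C(NCCCCc1ccccc1)c1cccc(C2OCC(=O)N2c2cccc(F)c2)c1`: 25%

Compound 1 and compound 2 share the same amide-bearing core and were both tested in a functional assay on U2OS cells (Homo sapiens) for inhibition, read by CCK-8 assay, with a stated time of 72 h, tested at 1 uM; a lower number here means less inhibition, a higher number more inhibition at the concentration tested (going by the name of the read-out). In this assay compound 1 gives 32%, and compound 2 gives 25%. Of the two numbers, that of compound 1 is the larger one, but the gap between them lies within the usual scatter of such measurements, so the two compounds cannot be told apart on these readings. Going by the values given here, compound 2 differs from compound 1 in more than one place, and no single-point step between measured compounds is available.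

Compound 3, `O=C(NCCCCc1ccccc1)c1cccc(C2SCC(=O)N2c2ccccc2F)c1`, has not been measured. It differs from compound 1 in one place: 2-fluorophenyl in place of 5-fluoro-2-methoxyphenyl on an amide-type nitrogen in a ring. Among the compounds with values here, nothing among the measured compounds isolates this change. The step from compound 1 to compound 3 in this assay is therefore expected to be small, a number 4 percentage points lower from compound 1 to compound 3 (within the scatter), with no direction that can be claimed beyond the scatter. Compound 3 is estimated to give 28%, in a range from 10% to 46%.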

Compound 3, a percentage reported as inhibition, at one concentration (the size of the read-out at that concentration, not a potency): 38%
The estimate for compound 3 lay 10 percentage points below the measured number, within the range that was stated.
By their numbers in this assay, from the lowest: compounds 2, 1 and 3 (each within the scatter of the next, the first and the last beyond it).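

In this assay, going by these compounds alone, the change on the amide-type nitrogen in the ring gives the first step between measured compounds that differ in one place: a number 6 percentage points higher from compound 1 to compound 3 (within the scatter) when 2-fluorophenyl takes the place of 5-fluoro-2-methoxyphenyl. At this position, then, the group can go from one with 1 hydrogen-bond acceptor to one with 0 without a change that can be told from the scatter, and the methoxy group is not required for a reading of this size at the single concentration tested. Nothing available explains why the two readings lie so close together, and the step gives no direction that can be claimed.

The compounds shown leave open whether any group at this position can move the reading beyond the scatter, for example an unsubstituted phenyl, a pyridyl ring or a phenyl carrying an amine or a carboxylic acid. They also leave open how much of the reading depends on the fluorine, since both aryl groups here carry one, and whether the same change would hold in the compounds with the other ring in the core.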